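This account rests on a few compounds, and the source may have more. Where it says the series, first, only, none or still open, it means among the compounds named here.

Working notes on the series, read in an assay on cells with melanin-concentrating hormone receptor 1 (Homo sapiens) as the target, read by radioligand binding; on this read-out lower numbers stand for stronger inhibition and higher numbers for weaker inhibition:
- compound 1 `CCOCC(C)Oc1cccc2ccc(N)nc12`: 1070 nM
- compound 2 `Nc1ccc2cccc(OCC3CCOC3)c2n1`: 115 nM
- compound 3 `COCC(C)Oc1cccc2ccc(N)nc12`: 606 nM

Compound 3 stands second highest of the three numbers in this assay. Its nearest neighbour is compound 1, separated by a 1.8-fold lower number from compound 1 to compound 3 (0.25 log units; within the scatter); its furthest is compound 2, separated by a 5.3-fold higher number from compound 2 to compound 3 (0.72 log units; beyond the scatter). Among the compounds with values here, the only change beyond the scatter seen so far is a 9.3-fold lower number from compound 1 to compound 2 (0.97 log units; beyond the scatter), so the group on the oxygen on the aromatic ring does move the number, and by a modest amount at most.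

Compound 4 `CC(C)(C)CCOc1cccc2ccc(N)nc12` is the step from compound 3: 3,3-dimethylbutyl in place of 1-(methoxymethyl)ethyl on an oxygen on an aromatic ring. Within the data shown here, no measured pair covers the loss of the hydrogen-bond acceptor from this group; the two steps that bear on it are a 9.3-fold lower number from compound 1 to compound 2 (0.97 log units; beyond the scatter) and a 1.8-fold lower number from compound 1 to compound 3 (0.25 log units; within the scatter), both changes of shape within side chains that all keep an ether oxygen. On that basis the expected change in this assay is small to modest and its direction is uncertain; the estimate is a 1.3-fold higher number from compound 3 to compound 4 (0.12 log units; within the scatter), with a range wide enough to cover a loss of the same size as the largest step seen. Compound 4 is thus estimated at 800 nM, between 150 nM and 4000 nM.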

Compound 4, half-maximal inhibitory concentration: 201 nM
Beside the measured number, compound 4's estimate is 4.0-fold (0.60 log units) above it, within the range that was stated.
By their numbers in this assay, from the lowest: compounds 2 and 4 (each within the scatter of the next); then compounds 3 and 1 (each within the scatter of the next).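

Working from this assay, the group on the oxygen on an aromatic ring does not need an ether oxygen to reach the lower numbers of the series: 3,3-dimethylbutyl, all carbon and with 0 hydrogen-bond acceptors, gives a 3.0-fold lower number from compound 3 to compound 4 (0.48 log units; beyond the scatter) and a 5.3-fold lower number from compound 1 to compound 4 (0.73 log units; beyond the scatter), so replacing an open-chain ether with this group moves the number beyond the scatter both times. The ring of the (oxolan-3-yl)methyl group is not needed either, since neopentyl in place of oxolan-3-yl on the saturated chain carbon gives a 1.7-fold higher number from compound 2 to compound 4 (0.24 log units; within the scatter), a step that leaves the two groups indistinguishable here. Nothing available bears on the reason for these differences.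

The compounds shown leave open how the number responds to a group on this oxygen that ends in an amine or a carboxylic acid, neither of which appears among them. They also leave open whether a longer unbranched carbon chain, or a carbocyclic ring such as cyclohexyl, would match 3,3-dimethylbutyl, so the limits on size and shape at this position remain undefined.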